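The compounds below may be only part of what the source reports. "The series", "measured", "known", "first", "only" and "open" are said of these compounds alone.

Measured in a functional assay on HeLa cells (Homo sapiens) for antiproliferative activity, read by MTT assay, with a stated time of 72 h; a higher number here means a weaker inhibitor, a lower number a stronger inhibitor:
- Compound 1 `COc1ncc(-c2ccc3c(c2)N(c2ccc(C)cc2)C(=O)CO3)cc1NS(=O)(=O)c1ccc(F)cc1`: 4650 nM
- Compound 2 `COc1ncc(-c2ccc3c(c2)NC(=O)CO3)cc1NS(=O)(=O)c1ccc(F)cc1`: 7110 nM
- Compound 3 `COc1cccc(N2C(=O)COc3ccc(-c4cnc(OC)c(NS(=O)(=O)c5ccc(F)cc5)c4)cc32)c1`: > 40000 nM (a limit of the assay, not a number)

Compound 3 sits at the limit of > 40000 nM in this assay, at which 1 of the 3 values shown sits, so it has a limit and no number, and it is the weakest of the three. Compound 4 `COc1ncc(-c2ccc3c(c2)N(c2ccc(F)cc2)C(=O)CO3)cc1NS(=O)(=O)c1ccc(F)cc1` keeps the shared core and changes one group: 4-fluorophenyl in place of 3-methoxyphenyl on an amide-type nitrogen in a ring. This places 4-fluorophenyl where compound 3 has 3-methoxyphenyl, on an amide-type nitrogen in a ring.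

Three measured steps at this same place bear on the change. Moving to 3-methoxyphenyl gave an at least 8.6-fold higher number from compound 1 to compound 3 (0.93 log units; beyond the scatter) and an at least 5.6-fold higher number from compound 2 to compound 3 (0.75 log units; beyond the scatter), while exchanging 4-methylphenyl for hydrogen gave a 1.5-fold higher number from compound 1 to compound 2 (0.18 log units; within the scatter). Only 3-methoxyphenyl has stood apart so far. The 4-fluorophenyl is expected to behave more like the 4-methylphenyl of compound 1, at 4650 nM, so a lower number is expected in this assay. No 4-fluorophenyl has been measured here, so the range is wide.

The expected change is an at least 5.7-fold lower number from compound 3 to compound 4 (0.75 log units; beyond the scatter). For compound 4 the estimate is 7000 nM, with an expected range of 2500 nM to 25000 nM.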

Compound 4, half-maximal inhibitory concentration: 10500 nM
Estimate against measurement, compound 4: 1.5-fold (0.18 log units) below, within the range that was stated.
By their numbers in this assay, from the lowest: compounds 1, 2 and 4 (each within the scatter of the next, the first and the last beyond it). At a limit, above all of these: compound 3.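

In this assay, 4-fluorophenyl in place of 3-methoxyphenyl on the amide-type nitrogen gives an at least 3.8-fold lower number from compound 3 to compound 4 (0.58 log units; beyond the scatter), so the loss seen with 3-methoxyphenyl is not shared by every substituted phenyl group at this place. The choice of group on the phenyl ring still registers, though modestly: fluoro in place of methyl gives a 2.3-fold higher number from compound 1 to compound 4 (0.35 log units; beyond the scatter), while the step from the amide hydrogen, a 1.5-fold higher number from compound 2 to compound 4 (0.17 log units; within the scatter), stays within the scatter. The value of compound 3 is a limit of the assay and not a number: the limit of > 40000 nM in this assay, at which 1 of the 4 values shown sits.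

The compounds shown leave open whether the loss goes with the methoxy group itself or with its placing in 3-methoxyphenyl, a question that 4-methoxyphenyl and 3-fluorophenyl on this nitrogen would address. Also open, from the compounds shown here alone, is how a phenyl ring carrying an amine or a carboxylic acid would read in this assay.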